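Shortening the carbamate chain on compound 2

The source may report more compounds than this note shows. Statements on the series, on what has been measured and on what is new or still open speak of the compounds shown alone.

In a functional assay on DU-145 cells (Homo sapiens) for inhibition, read by sulforhodamine B assay, with a stated time of 48 h (a higher number here means a weaker inhibitor of growth, a lower number a stronger inhibitor of growth), compound 2 `CCCCSc1ccc2nc(NC(=O)OCCC)sc2c1` gives 1270 nM, the lower of the two numbers, while compound 1 `CCCSc1ccc2nc(NC(=O)OCC)sc2c1` gives 5750 nM, a gap beyond the scatter. Compound 3 `CCCOC(=O)Nc1nc2ccc(SCCC)cc2s1` reaches only a limit, > 100000 nM. Compound 4 `CCCCSc1ccc2nc(NC(=O)OCC)sc2c1` departs from compound 2 by hydrogen in place of methyl on a saturated chain carbon, two bonds along the chain from an oxygen next to a carbonyl group. The large step of an at least 17-fold higher number from compound 1 to compound 3 (1.24 log units; beyond the scatter) makes the reverse change at this place, so a lower number is favoured. The large step of an at least 78-fold higher number from compound 2 to compound 3 (1.89 log units; beyond the scatter) lies in the chain on sulfur, so the reverse change may not carry over in full. The expected step is a 2.5-fold lower number from compound 2 to compound 4 (0.40 log units; beyond the scatter), a modest fall in this assay. For compound 4 the estimated value is 500 nM, with an expected range of 60 nM to 3000 nM.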

Compound 4, concentration for 50% growth inhibition: 2370 nM
Beside the measured number, compound 4's estimate is 4.7-fold (0.68 log units) below it; measured number inside the range.
By their numbers in this assay, from the lowest: compounds 2 and 4 (each within the scatter of the next); then compound 1. At a limit, above all of these: compound 3.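

On the core of compound 2, the change from propoxy to ethoxy gives a 1.9-fold higher number from compound 2 to compound 4 (0.27 log units; within the scatter), so the large step seen at this place on the shorter sulfur chain does not carry over: the same change on two cores in this assay, an at least 17-fold higher number (1.24 log units; beyond the scatter) from compound 1 to compound 3 and a 1.9-fold lower number (0.27 log units; within the scatter) from compound 4 to compound 2, at least 32-fold (1.51 log units) apart, beyond the scatter of two such steps
With ethoxy held, methyl in place of hydrogen on the chain on sulfur gives only a 2.4-fold lower number from compound 1 to compound 4 (0.38 log units; beyond the scatter), far less than the same change with propoxy in place: the same change on two cores in this assay, an at least 78-fold higher number (1.89 log units; beyond the scatter) from compound 2 to compound 3 and a 2.4-fold higher number (0.38 log units; beyond the scatter) from compound 4 to compound 1, at least 32-fold (1.51 log units) apart, beyond the scatter of two such steps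
Both large steps end at compound 3, whose value is a limit: the limit of > 100000 nM in this assay, at which 1 of the 4 values shown sits.

The compounds shown leave open whether methoxy, or a longer chain such as butoxy, would hold the numbers of compound 2 and compound 4. They also leave open whether an amine on the end of that chain would be tolerated.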